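The source may hold more compounds than are shown below. What is called first, only, known or untested is meant among the compounds shown, and "the series" means these compounds.

Compound 1 `CC(C)c1ccccc1NC(=O)N[C@@H](C)c1ccccc1` and compound 2 `CC(C)c1cccc(NC(=O)N[C@H](C)c2ccccc2)c1` hold the same atoms joined differently; the difference between the two cores is not broken down here. In an ADME assay on the whole organism with Oryza sativa as the target, tested at 1 uM (on this read-out higher numbers stand for a weaker effect at the one concentration tested and lower numbers for a stronger effect), compound 1 gives 96%, and compound 2 gives 61%. Compound 3 `C[C@H](NC(=O)Nc1ccccc1C(F)(F)F)c1ccccc1` comes from compound 1 by trifluoromethyl in place of isopropyl on an aromatic carbon; here a number 2 percentage points higher from compound 1 to compound 3 (within the scatter), and in this assay compound 3 gives 98%. Compound 4 `C[C@@H](NC(=O)Nc1cccc(C(F)(F)F)c1)c1ccccc1`, not yet measured, comes from compound 2 by trifluoromethyl in place of isopropyl on an aromatic carbon. This is the same kind of change, though the surroundings differ: in compound 3 the trifluoromethyl sits ortho to a large group, in compound 4 meta to a large group. For compound 4 in this assay a step of a number 2 percentage points higher from compound 2 to compound 4 (within the scatter) is expected, resting on a number 2 percentage points higher from compound 1 to compound 3 (within the scatter). Compound 4 is accordingly estimated at 63%, between 45% and 80%.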

Compound 4, a percentage reported as activity, at one concentration (the size of the read-out at that concentration, not a potency): 72%
Compound 4: middle estimate off by 9 percentage points, on the low side; measured number inside the range.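

In this assay, trifluoromethyl in place of isopropyl gives a number 11 percentage points higher from compound 2 to compound 4 (beyond the scatter), a modest step. Set beside the earlier step, the change reads alike on the two cores: the same change on two cores in this assay, a number 2 percentage points higher (within the scatter) from compound 1 to compound 3 and a number 11 percentage points higher (beyond the scatter) from compound 2 to compound 4, 9 percentage points apart, within the scatter of two such steps. This supports carrying the change between these two cores, but two steps make no rule for the series, and they do not explain why one step lies within the scatter and the other beyond it.

Still open, going by these compounds, is how other groups at this place would read, such as a nitrile, an amine or a carboxylic acid. Also open, on these data alone, is whether the change would read alike on a third core.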